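Shortening the ester acyl chain on the shared core

This account rests on a few compounds, and the source may have more. Where it says the series, first, only, none or still open, it means among the compounds named here.

Going by the values given here, compound 2 `CCCCCCC(=O)OCc1ccc2oc(=O)c(C(=O)Oc3cccc(Br)c3)cc2c1` stands highest of the two numbers so far, giving 89.4% in a functional assay on HT-1080 cells (Homo sapiens), read by transwell migration, with a stated time of 24 h, tested at 0.1 uM; a higher number here means a weaker effect of the compound at the concentration tested, a lower number a stronger effect. Its nearest neighbour is compound 1 `CC(=O)OCc1ccc2oc(=O)c(C(=O)Oc3cccc(Br)c3)cc2c1`, which gives 39.5% in this assay. Among the compounds with values here, the only measured step, a number 49.9 percentage points higher from compound 1 to compound 2 (beyond the scatter), is the single point of reference for the series. Compound 3 `CC(C)C(=O)OCc1ccc2oc(=O)c(C(=O)Oc3cccc(Br)c3)cc2c1` is not yet measured and differs from compound 2 by isopropyl in place of hexyl on a carbonyl carbon. This change shortens the chain on the carbonyl carbon, running against the direction of the measured step, so a fall in the percentage is expected rather than a rise. The step of a number 34.4 percentage points lower from compound 2 to compound 3 (beyond the scatter) is expected to lie beyond the scatter because a number 49.9 percentage points higher from compound 1 to compound 2 (beyond the scatter) was itself large. Within the data shown here, for compound 3 a value of 55% is estimated, with a range from 35% to 78%, since only one step supports the estimate.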

Compound 3, a percentage reported as activity, at one concentration (the size of the read-out at that concentration, not a potency): 54.4%
Compound 3: middle estimate off by 0.6 percentage points, on the high side; the range from low to high includes it.
By their numbers in this assay, from the lowest: compound 1; then compound 3; then compound 2.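

Working notes on the group on the carbonyl carbon: in this assay, isopropyl in place of hexyl gives a number 35 percentage points lower from compound 2 to compound 3 (beyond the scatter), while isopropyl in place of methyl gives a number 14.9 percentage points higher from compound 1 to compound 3 (beyond the scatter), so this position now yields three separated numbers rather than a single contrast. Across these three compounds the number rises from methyl through isopropyl to hexyl, and none of them goes against that order, although isopropyl is branched and hexyl is not, so chain size and branching remain entangled. No available data bear on the reason for these steps.

Open, going by these compounds, is whether a straight propyl chain would give a number close to that of compound 3. Also open, on these data alone, is whether an acyl group carrying an amine or a phenyl ring would fit the same order.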